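Carboxylic acid in place of methoxy on the pyridine

This account rests on a few compounds, and the source may have more. Where it says the series, first, only, none or still open, it means among the compounds named here.

Of the compounds shown here, two have been measured. Compound 1 `O=C(O)c1ccc(-c2cnc(C(=O)CCCCCCc3ccccc3)o2)cc1` gives 60 nM in an assay (Rattus norvegicus) for inhibition of Fatty-acid amide hydrolase 1 (Homo sapiens); on this read-out lower numbers stand for stronger inhibition and higher numbers for weaker inhibition. Compound 2 `COc1ccnc(-c2cnc(C(=O)CCCCCCc3ccccc3)o2)c1` gives 0.8 nM in this assay and stands lowest of the two numbers; the nearest is compound 1, a 75-fold lower number from compound 1 to compound 2 (1.88 log units; beyond the scatter).

Compound 3 `O=C(CCCCCCc1ccccc1)c1ncc(-c2ncccc2C(=O)O)o1` has not yet been measured. The change from compound 2 to compound 3 is 3-carboxypyridin-2-yl in place of 4-methoxypyridin-2-yl on an aromatic carbon.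

Going by the values given here, one measured step bears on this. The step from compound 1 to compound 2 replaced a carboxyphenyl with a methoxypyridinyl and was large, a 75-fold lower number from compound 1 to compound 2 (1.88 log units; beyond the scatter). Compound 3 returns a carboxylic acid to the ring that carries the large group, yet keeps the pyridine of compound 2, so only part of that step is undone. The expectation is therefore a step in this assay back toward compound 1, beyond the scatter, though smaller than the whole of the measured step. For compound 3 the estimate in this assay is 15 nM, with a range from 3 nM to 80 nM, which means an expected step of a 19-fold higher number from compound 2 to compound 3 (1.27 log units; beyond the scatter).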

Compound 3, inhibition constant: > 50 nM
Compound 3: no number, only a limit; the forecaster's own chance of this, stated with the estimate: 5%; middle value at least 3.3-fold (0.52 log units) from the limit.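

Compound 3 gives no number in this assay, only a limit: the limit of > 50 nM in this assay, at which 1 of the 3 values shown sits.

Even so, the change on this aromatic carbon, next to the ring oxygen of the five-membered ring, is large, an at least 62-fold higher number from compound 2 to compound 3 (1.79 log units; beyond the scatter), so a pyridine at this place does not by itself hold the low number of compound 2 once 3-carboxypyridin-2-yl stands in place of 4-methoxypyridin-2-yl. Compound 1 had shown a higher number only with a carboxylic acid on a phenyl ring, whereas compound 3 shows that a carboxylic acid on a pyridine also stands far from compound 2, while the step between compound 1 and compound 3 cannot be read.

Compound 3 differs from compound 2 both in the group on the pyridine and in where that group sits, so the compounds shown do not separate the carboxylic acid itself from its place on the ring. A methyl ester or a primary amide in place of the carboxylic acid on the same pyridine would bear on that question.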